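Dropping the methoxy from the anilide of compound 3

This account rests on a few compounds, and the source may have more. Where it says the series, first, only, none or still open, it means among the compounds named here.

Measured compounds:
Compound 1, `COc1ccc2nc(C)cc(OCC(=O)Nc3cc(F)cc(F)c3)c2c1`: 13000 nM
Compound 2, `COc1ccc2nc(C)cc(OCC(=O)Nc3ccc(Cl)c(C(F)(F)F)c3)c2c1`: 17000 nM
Compound 3, `COc1ccc2nc(C)cc(OCC(=O)Nc3ccc(Cl)c(OC)c3)c2c1`: 13000 nM

All three were tested in a physicochemical assay for solubility, in phosphate buffer, measured as kinetic solubility, with a stated time of 1 h, at pH 7.4; on this read-out lower numbers stand for lower solubility and higher numbers for higher solubility. Compound 3 stands level with compound 1 and, with it, at the lower end of the three numbers; the remaining gap is a 1.3-fold lower number from compound 2 to compound 3 (0.12 log units; within the scatter). Compound 4, `COc1ccc2nc(C)cc(OCC(=O)Nc3ccc(Cl)cc3)c2c1`, has not been measured. It differs from compound 3 by hydrogen in place of methoxy on an aromatic carbon. For the measured compounds named here, two measured steps bear on this. Exchanging the whole anilide ring gave no change at the digits printed from compound 1 to compound 3 (within the scatter), and swapping one substituent for another gave a 1.3-fold lower number from compound 2 to compound 3 (0.12 log units; within the scatter). Both sit within the scatter, so a substituent change of this kind is expected to leave this assay essentially unmoved. The expected step is no change at the digits printed from compound 3 to compound 4 (within the scatter). Compound 4 is therefore estimated at 13000 nM, with a range from 6000 nM to 28000 nM.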

Compound 4, solubility: 9000 nM
Estimate against measurement, compound 4: 1.4-fold (0.16 log units) above; low and high end bracket the measured number.
By their numbers in this assay, from the lowest: compounds 4, 1, 3 and 2 (each within the scatter of the next).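

In this assay, taking the methoxy off the anilide ring gives a 1.4-fold lower number from compound 3 to compound 4 (0.16 log units; within the scatter) and leaves a bare hydrogen ortho to a chloro group. Set against trifluoromethyl at that place, the hydrogen gives a 1.9-fold lower number from compound 2 to compound 4 (0.28 log units; within the scatter), while exchanging the whole ring gives a 1.4-fold lower number from compound 1 to compound 4 (0.16 log units; within the scatter), so an unsubstituted carbon here still leaves every step within the scatter. Nothing measured here accounts for the size of these steps.

Open, on these data alone, is whether an amine or a carboxylic acid at this place would carry the read-out beyond the scatter.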